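This account rests on a few compounds, and the source may have more. Where it says the series, first, only, none or still open, it means among the compounds named here.

Measured in a functional assay on A549 cells (Homo sapiens) for antiproliferative activity, read by MTT assay; on this read-out lower numbers stand for stronger inhibition and higher numbers for weaker inhibition:
Compound 1, `Cc1ccc(NC(=O)Nc2cccc(CNc3ncnc4ccccc34)c2)cc1`: 24900 nM
Compound 2, `CC(C)(C)c1ccc(NC(=O)Nc2cccc(CNc3ncnc4ccccc34)c2)cc1`: 17900 nM
Compound 3, `O=C(Nc1ccc([N+](=O)[O-])cc1)Nc1cccc(CNc2ncnc3ccccc23)c1`: a limit of the assay, > 50000 nM

Among the two numbers, compound 2 sits lowest, with compound 1 nearest: a 1.4-fold lower number from compound 1 to compound 2 (0.14 log units; within the scatter). Compound 3 gives only a limit, (the limit of > 50000 nM in this assay, at which 1 of the 3 values shown sits), and an at least 2.0-fold higher number from compound 1 to compound 3 (0.30 log units; that floor lies within the scatter) while an at least 2.7-fold higher number from compound 2 to compound 3 (0.44 log units; beyond the scatter). Compound 4, `O=C(Nc1cccc(CNc2ncnc3ccccc23)c1)Nc1cccc(C(F)(F)F)c1`, differs from compound 2 in one place: 3-(trifluoromethyl)phenyl in place of 4-(tert-butyl)phenyl on an amide-type nitrogen. The steps from compound 2 bear on it only loosely, a small change in one direction and a modest weakening with nitro in the other. For compound 4 the step of a 1.4-fold higher number from compound 2 to compound 4 (0.15 log units; within the scatter) is therefore expected to be small. Compound 4 is estimated at 25000 nM in this assay, within 11000 nM to 50000 nM.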

Compound 4, half-maximal inhibitory concentration: 44200 nM
Beside the measured number, compound 4's estimate is 1.8-fold (0.25 log units) below it, within the range that was stated.
By their numbers in this assay, from the lowest: compounds 2, 1 and 4 (each within the scatter of the next, the first and the last beyond it). At a limit, above all of these: compound 3.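

In this assay, a replacement on the amide-type nitrogen other than 4-nitrophenyl now moves the number beyond the scatter, with 3-(trifluoromethyl)phenyl: a 2.5-fold higher number from compound 2 to compound 4 (0.39 log units; beyond the scatter). With 3-(trifluoromethyl)phenyl in place of 4-methylphenyl, the step lies within the scatter: a 1.8-fold higher number from compound 1 to compound 4 (0.25 log units; within the scatter). Compound 3 gives only a limit: the limit of > 50000 nM in this assay, at which 1 of the 4 values shown sits.
The step from that limit is therefore only a floor, and it lies within the scatter: an at least 1.1-fold lower number from compound 3 to compound 4 (0.05 log units; that floor lies within the scatter).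

Compound 4 changes both the group and its place on the ring, and these compounds do not separate the two. On these data alone, how an amine or a carboxylic acid on this phenyl ring would read remains open.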